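The compounds below may be only part of what the source reports. "The series", "measured", "known", "first", "only" and "open" are said of these compounds alone.

The measured compounds are compound 1 `COc1cc(OC)c(C2CC(c3ccco3)=NN2C(C)=O)cc1OC` with 7760 nM and compound 2 `O=CCN1N=C(c2ccc3ccccc3c2)CC1c1cccc([N+](=O)[O-])c1` with 3280 nM.

Among the compounds with values here, in a functional assay on IMR-32 cells (Homo sapiens) for cytotoxicity, read by sulforhodamine B assay, with a stated time of 48 h (on this read-out higher numbers stand for weaker inhibition and lower numbers for stronger inhibition), compound 2 gives 3280 nM, the lowest of the two numbers measured so far. Compound 1 gives 7760 nM in this assay, a higher number, and the gap between the two lies beyond the usual scatter. Within the data shown here, compound 1 and compound 2 differ in several places at once, so no single step can be read from them; their two values show only that compound 2 sits lower.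

Compound 3 `O=CCN1N=C(c2ccc3ccccc3c2)CC1c1cccc(Cl)c1Cl` has not yet been measured. It differs from compound 2 in one place: 2,3-dichlorophenyl in place of 3-nitrophenyl on a saturated ring carbon. Among the measured compounds shown here, no measured pair in this set shows the effect of such an exchange, so there is no step on which to lean, and the expectation rests on compound 2 alone. Compound 3 is expected to sit close to its parent, with an expected step of a 1.1-fold lower number from compound 2 to compound 3 (0.04 log units; within the scatter) that would lie within the usual scatter. For compound 3 in this assay the estimate is 3000 nM, with a range from 1000 nM to 10000 nM.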

Compound 3, half-maximal inhibitory concentration: 16900 nM
The estimate for compound 3 lay 5.6-fold (0.75 log units) below the measured number, and the stated range ends below it.
By their numbers in this assay, from the lowest: compound 2; then compound 1; then compound 3.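

Within the data shown here, the step of a 5.2-fold higher number from compound 2 to compound 3 (0.71 log units; beyond the scatter) is the only single-place comparison in this set, and it shows that in this assay the read-out is not indifferent to the aromatic group on this saturated ring carbon of the five-membered ring. With everything else held fixed, including the formylmethyl group on the ring nitrogen, 3-nitrophenyl gives the lower number of the two groups compared here, and 2,3-dichlorophenyl gives the higher. No independent measurement is available here to explain this rise.

The compounds shown leave open whether the step follows from the loss of the nitro group or from the arrival of the two chlorine atoms, since both happen in one exchange; a plain phenyl ring, a phenyl ring with a single chlorine, or an amine or methoxy group in place of the nitro group would pull these apart. They also leave open whether the same exchange would move the number in the same direction on the core of compound 1, which carries an acetyl group in place of the formylmethyl group.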